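Anilino variation on the shared core: cytotoxicity notes

The source may report more compounds than this note shows. Statements on the series, on what has been measured and on what is new or still open speak of the compounds shown alone.

Going by the values given here, compound 2 `CCS(=O)(=O)Nc1cc(-c2ccc3ncnc(Nc4ccc(OC)c(Cl)c4)c3c2)cnc1OC` is the lower of the two numbers measured in a functional assay on MCF7 cells (Homo sapiens) for cytotoxicity, read by sulforhodamine B assay, with a stated time of 72 h; on this read-out higher numbers stand for weaker inhibition and lower numbers for stronger inhibition: compound 2 gives 3320 nM, and its one neighbour, compound 1 `CCS(=O)(=O)Nc1cc(-c2ccc3ncnc(Nc4ccc(F)cc4)c3c2)cnc1OC`, gives 6510 nM in this assay. The step between them, a 2.0-fold lower number from compound 1 to compound 2 (0.29 log units; within the scatter), is the only one measured so far and it stays within the scatter, so the two aryl groups on the nitrogen on the aromatic ring cannot be told apart on these data.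

Compound 3 `CCS(=O)(=O)Nc1cc(-c2ccc3ncnc(Nc4ccc(F)c(C(=O)OC)c4)c3c2)cnc1OC` differs from compound 2 in one place: 4-fluoro-3-(methoxycarbonyl)phenyl in place of 3-chloro-4-methoxyphenyl on a nitrogen on an aromatic ring. Part of what enters, the fluorine on the aryl ring, was already present in compound 1; the methoxycarbonyl group has no precedent in the series. Among the compounds with values here, the only step that bears on this change, from compound 1 to compound 2, was within the scatter, and nothing measured speaks for the added ester. A step within the scatter in this assay is therefore expected, a 1.2-fold higher number from compound 2 to compound 3 (0.08 log units; within the scatter). Compound 3 is estimated at 4000 nM in this assay, with a range from 1300 nM to 12000 nM.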

Compound 3, half-maximal inhibitory concentration: 1150 nM
Compound 3: middle estimate off by 3.5-fold (0.54 log units), on the high side; the measured number lies below the stated range.
By their numbers in this assay, from the lowest: compound 3; then compounds 2 and 1 (each within the scatter of the next).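

Going by these compounds alone, at this anilino position, a 5.7-fold lower number from compound 1 to compound 3 (0.75 log units; beyond the scatter) in this assay gives the first readable step, with methoxycarbonyl in place of hydrogen on an aromatic carbon as the single change from the 4-fluorophenyl group. The modest 2.9-fold lower number from compound 2 to compound 3 (0.46 log units; beyond the scatter) also separates 4-fluoro-3-(methoxycarbonyl)phenyl from 3-chloro-4-methoxyphenyl, so the aryl group on the nitrogen now registers in this read-out, and compound 3 stands apart from both earlier compounds, which remain within the scatter of each other. No measurement on hand gives a reason for the lower number of compound 3, so the shift remains an observation on these three compounds only.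

Going by these compounds, whether the shift depends on the methoxycarbonyl group as such remains open, since a carboxylic acid, a primary amide or a nitrile on that aromatic carbon would be needed to show whether the ester can be replaced. Also open, on these data alone, is the part played by the fluorine in 4-fluoro-3-(methoxycarbonyl)phenyl, which a comparison with 3-(methoxycarbonyl)phenyl, or with a chlorine in place of that fluorine, would address.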